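The compounds below may be only part of what the source reports. "The series", "measured", "known", "first", "only" and "open" are said of these compounds alone.

Measured so far in a functional assay on OCI-Ly3 cells (Homo sapiens) for inhibition, read by CellTiter-Glo, with stated times of 48 h and 96 h; a lower number here means a stronger inhibitor of growth, a higher number a weaker inhibitor of growth:
- compound 1 `CC(C)[C@H](NC(=O)c1ccc(Cl)cc1)C(=O)N1CCC[C@H]1C(=O)N[C@@H](CCCNC(=N)N)C(=O)CF` gives 1240 nM
- compound 2 `CC(C)[C@H](NC(=O)c1ccc(C(F)(F)F)cc1)C(=O)N1CCC[C@H]1C(=O)N[C@@H](CCCNC(=N)N)C(=O)CF` gives 120 nM

Compound 2 stands lowest of the two, and its nearest neighbour is compound 1. The measured change between them is a 10-fold lower number from compound 1 to compound 2 (1.01 log units; beyond the scatter), a large step beyond the scatter, with trifluoromethyl in place of chloro on an aromatic carbon.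

The next compound is compound 3 `CC(C)c1ccc(C(=O)N[C@H](C(=O)N2CCC[C@H]2C(=O)N[C@@H](CCCNC(=N)N)C(=O)CF)C(C)C)cc1`, which keeps the shared core and differs from compound 2 in one group: isopropyl in place of trifluoromethyl on an aromatic carbon. In words, isopropyl stands in place of trifluoromethyl on an aromatic carbon, para to a large group.

Among the compounds with values here, only that one measured step bears on this change, and no measured compound carries isopropyl, so the data give no direct direction. The step of a 10-fold lower number from compound 1 to compound 2 (1.01 log units; beyond the scatter) shows that a swap of this group can move the number in this assay by a large amount. Since compound 2 holds the lower of the two values, a higher number is expected, though by less than that measured step.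

The estimated step is a 2.9-fold higher number from compound 2 to compound 3 (0.46 log units; beyond the scatter) in that direction. For compound 3 the expected value is 350 nM, with an estimated range from 100 nM to 1300 nM as its limits.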

Compound 3, concentration for 50% growth inhibition: 270 nM
The estimate for compound 3 lay 1.3-fold (0.11 log units) above the measured number; measured number inside the range.
By their numbers in this assay, from the lowest: compound 2; then compound 3; then compound 1.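

Carrying isopropyl in place of trifluoromethyl on this aromatic carbon, para to a large group, gives a 2.3-fold higher number from compound 2 to compound 3 (0.35 log units; beyond the scatter) in this assay, so trifluoromethyl is not matched here, although the loss is modest. Set against chloro, isopropyl still gives a 4.6-fold lower number from compound 1 to compound 3 (0.66 log units; beyond the scatter), which shows that a group with no halogen, made of carbon only, keeps much of the gain seen with trifluoromethyl and that fluorine is not needed for a number well under that of compound 1. Across these three compounds, the position separates all three groups beyond the scatter, with trifluoromethyl lowest, isopropyl in the middle and chloro highest, but nothing at hand accounts for that order.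

The compounds shown leave open how a tert-butyl, a nitrile, a methoxy or an amine on the same aromatic carbon would read in this assay, and so whether any group can go lower than trifluoromethyl at this place. They also leave open whether this order of groups would hold if the rest of the shared core were changed, for instance if the fluoromethyl ketone gave way to a carboxylic acid.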